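The source may report more compounds than this note shows. Statements on the series, on what has been measured and on what is new or still open speak of the compounds shown alone.

Working notes on a small series of dithiocarbonate ketones carrying an amide.

Compound 1 `CCSC(=S)SCC(=O)c1cccc(C(=O)NCc2ccccc2)c1` gives 195 nM in an assay on HEK293 cells for inhibition of protein deacetylase HDAC6 (Homo sapiens); a higher number here means a weaker inhibitor, a lower number a stronger inhibitor. Compound 2 `CCSC(=S)SCC(=O)c1cccc(C(=O)Nc2ccccc2)c1` gives 517 nM in this assay. Between them the change is benzyl in place of phenyl on an amide-type nitrogen, and the step is a 2.7-fold lower number from compound 2 to compound 1 (0.42 log units; beyond the scatter).

Compound 3 `CCSC(=S)SCC(=O)c1ccc(C(=O)Nc2ccccc2)cc1` gives 521 nM in this assay; its value and that of compound 2 lie within the scatter of each other. Compound 3 and compound 2 have the same atoms joined differently; the difference between the two cores is not broken down here.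

Compound 4 `CCSC(=S)SCC(=O)c1ccc(C(=O)NCc2ccccc2)cc1` has not been measured. It differs from compound 3 by benzyl in place of phenyl on an amide-type nitrogen, the same change as that from compound 2 to compound 1 at the same kind of place. The expectation for compound 4 rests on that one earlier step, because compound 2 to compound 1 showed a 2.7-fold lower number from compound 2 to compound 1 (0.42 log units; beyond the scatter) on a different core. For compound 4 a step of about a 2.6-fold lower number from compound 3 to compound 4 (0.42 log units; beyond the scatter) is therefore expected in this assay. The estimate for compound 4 is 200 nM, in the range 90 nM to 450 nM.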

Compound 4, half-maximal inhibitory concentration: 830 nM
The estimate for compound 4 lay 4.2-fold (0.62 log units) below the measured number; the whole stated range lies below it.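

In this assay, going by these compounds alone, benzyl in place of phenyl on an amide-type nitrogen gives a 1.6-fold higher number from compound 3 to compound 4 (0.20 log units; within the scatter), so on the core of compound 3 the change produces no step that can be told from the scatter. The gain seen on the core of compound 1 therefore does not carry over to the core of compound 3, and in this series the change cannot be treated as transferable between these two cores: the same change on two cores in this assay, a 2.7-fold lower number (0.42 log units; beyond the scatter) from compound 2 to compound 1 and a 1.6-fold higher number (0.20 log units; within the scatter) from compound 3 to compound 4, 4.2-fold (0.63 log units) apart, beyond the scatter of two such steps. This rests on a single pair per core, so it does not show what in the two cores separates the outcomes, nor how the change would behave on any further core.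

The compounds shown leave open how a longer chain, such as phenethyl, would behave on the amide-type nitrogen of either core. They also leave open whether the same contrast between the two cores would persist with a hydroxamic acid in place of the dithiocarbonate ketone.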